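Chloro to hydrogen on compound 1

The compounds below may be only part of what the source reports. "The series", "measured", "known", "first", "only" and "open" are said of these compounds alone.

In a physicochemical assay for acid dissociation, compound 1 `CN(Cc1ccc(Cl)cc1)Cc1ccccc1CNc1ccnc2cc(Cl)ccc12` gives 7.44 and compound 2 `CN(Cc1ccc(N(C)C)cc1)Cc1cccc(CNc2ccnc3cc(Cl)ccc23)c1` gives 7.36 as its reading, so the two stand level within the usual scatter. Compound 3 `CN(Cc1ccccc1)Cc1ccccc1CNc1ccnc2cc(Cl)ccc12` carries hydrogen in place of chloro on an aromatic carbon and so turns the 4-chlorobenzyl of compound 1 into benzyl. Among the compounds with values here, no pair of measured compounds isolates this change, and compound 2 differs from compound 1 in more than one place, so the data offer no direct measure of it. The expectation therefore rests on the structural change alone, and it is a small upward move in this assay of about the size of the scatter. The expected step is a number 0.26 log units higher from compound 1 to compound 3 (within the scatter) and it could prove indistinguishable from no change. For compound 3 the estimated value is 7.7 with 7.4 to 8 as the expected range.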

Compound 3, acid dissociation constant: 7.57
Estimate against measurement, compound 3: 0.13 log units above, and the stated range covers the measured number.
By their numbers in this assay, from the lowest: compounds 2, 1 and 3 (each within the scatter of the next).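

In this assay, within the data shown here, the change from 4-chlorobenzyl to benzyl gives the only step that isolates a single place: a number 0.13 log units higher from compound 1 to compound 3 (within the scatter). Chloro on this aromatic carbon, para to a large group, can therefore be exchanged for hydrogen without the reading leaving the scatter, and compound 1 and compound 3 stand level. The earlier compounds shown here could not show this, since compound 2 differs from compound 1 in more than one place.

Still open, as far as these compounds go, is whether a different group at this position, such as methoxy, an amine or a carboxylic acid, would shift the reading beyond the scatter. No measured evidence bears on what lies behind this small step.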